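The compounds below may be only part of what the source reports. "The series", "measured", "known", "first", "only" and "open" are said of these compounds alone.

Measured in an assay on membranes from CHO cells for displacement of a labelled ligand from adenosine receptor A1 (Homo sapiens), read by scintillation counting, with a stated time of 60 min, tested at 1 uM; a lower number here means less inhibition, a higher number more inhibition at the concentration tested (going by the name of the read-out):

- compound 1 `COC(=O)C1=C(C)NC(=S)NC1c1ccoc1`: 25%
- compound 2 `COC(=O)C1=C(C)NC(=S)NC1c1cccs1`: 1%
- compound 3 `COC(=O)C1=C(C)N(C)C(=O)NC1c1ccoc1`: 15%

Compounds 1 and 2 share one core and differ only by thiophen-2-yl in place of furan-3-yl on a saturated ring carbon; this change gave a number 24 percentage points lower from compound 1 to compound 2 (beyond the scatter). Compound 3 sits on a different core; how the two cores differ is not broken down here. The values of compound 3 and compound 1 lie within the usual scatter of each other, so no order between them is claimed, while compound 3 stands beyond the scatter above compound 2.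

Compound 4 `COC(=O)C1=C(C)N(C)C(=O)NC1c1cccs1` has not yet been measured. It arises from compound 3 by thiophen-2-yl in place of furan-3-yl on a saturated ring carbon, the same kind of change as from compound 1 to compound 2; around the place, the surroundings are the same except that in compound 3 the saturated ring carbon is also three ring bonds from the ring atom that bears a methyl group.

Among the measured compounds shown here, the step is expected at a number 12 percentage points lower from compound 3 to compound 4 (beyond the scatter), a size taken from the earlier pair because a number 24 percentage points lower from compound 1 to compound 2 (beyond the scatter) is the only measured instance of this change. Compound 4 is expected at 3%, between -6% and 13%.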

Compound 4, a percentage reported as inhibition, at one concentration (the size of the read-out at that concentration, not a potency): 30%
Compound 4: middle estimate off by 27 percentage points, on the low side; the measured number lies above the stated range.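

In this assay, the change from furan-3-yl to thiophen-2-yl on the core of compound 3 gives a number 15 percentage points higher from compound 3 to compound 4 (beyond the scatter). Set beside the earlier step, this shows that neither the direction nor the size of the change carries over from one core to the other in this series: the same change on two cores in this assay, a number 24 percentage points lower (beyond the scatter) from compound 1 to compound 2 and a number 15 percentage points higher (beyond the scatter) from compound 3 to compound 4, 39 percentage points apart, beyond the scatter of two such steps. It does not show which feature of the cores sets the direction, or how either thiophen-2-yl compound would behave on a further core, since each core contributes a single pair read at one concentration, which is not a potency.

The compounds shown leave open which part of the difference between the two cores accounts for the opposite steps, and whether other groups on the saturated ring carbon would follow either core's pattern. Also open, going by these compounds, is what happens when a carboxylic acid or an amide takes the place of the methoxycarbonyl group, or when a longer chain takes the place of the ring methyl group.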